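A Third Methoxy Group on a Chalcone Scaffold

The source may report more compounds than this note shows. Statements on the series, on what has been measured and on what is new or still open speak of the compounds shown alone.

Compound 1 `O=C(/C=C/c1ccc(O)cc1)c1cc(Cc2c(O)ccc(C(=O)/C=C/c3ccc(O)cc3)c2O)c(O)cc1O`: > 10000 nM
Compound 2 `COc1ccc(C(=O)/C=C/c2cc(OC)c(OC)c(OC)c2)c(OC)c1`: 6600 nM

In a functional assay on MDA-MB-231 cells (Homo sapiens) for cytotoxicity, read by MTT assay, with a stated time of 72 h (a lower number here means a stronger inhibitor, a higher number a weaker inhibitor), compound 1 reaches only a limit, > 10000 nM, which is the limit of > 10000 nM in this assay, at which 1 of the 2 values shown sits. Compound 2 gives 6600 nM in this assay. Among the two results shown, this is the only number, so compound 2 stands alone as a numbered point of reference.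

Compound 3 `COc1cc(/C=C/C(=O)c2ccc(OC)c(OC)c2OC)cc(OC)c1OC` has not yet been measured. It differs from compound 2 by methoxy in place of hydrogen on an aromatic carbon: a methoxy replaces a hydrogen on an aromatic carbon of a six-membered aromatic ring of carbon only, ortho to two methoxy groups. Among the measured compounds shown here, no step between two measured compounds is available, so the size of this change in this assay cannot be drawn from the data; a small shift toward stronger inhibition, or none beyond the scatter, is the likeliest outcome. Compound 3 is expected to give 4000 nM in this assay, with a range of 1500 nM to 12000 nM. This expected result would mean a step of a 1.7-fold lower number from compound 2 to compound 3 (0.22 log units; within the scatter).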

Compound 3, half-maximal inhibitory concentration: 7400 nM
Compound 3: the middle estimate sits 1.9-fold (0.27 log units) below what was measured; the range from low to high includes it.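

Setting a methoxy in place of hydrogen on an aromatic carbon, ortho to two methoxy groups and meta to a large group, gives the first step that can be read in this assay: a 1.1-fold higher number from compound 2 to compound 3 (0.05 log units; within the scatter). The two compounds therefore cannot be told apart in this assay, and at this position the added methoxy leaves no mark beyond the usual scatter of repeated measurements. No measurement shown here bears on why this is so.

The compounds shown leave open whether an amine, a carboxylic acid or a longer chain at this same position would separate from hydrogen and methoxy in this assay. They also leave open whether a methoxy placed elsewhere on the shared core would give a step beyond the scatter.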